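This account rests on a few compounds, and the source may have more. Where it says the series, first, only, none or still open, it means among the compounds named here.

Measured compounds:
Compound 1, `Cc1ccnc(/C(N)=N/NC(=S)N2CCSCC2)c1`: 79.6%
Compound 2, `N/C(=N\NC(=S)N1CCSCC1)c1ccccn1`: 80.8%
Compound 3, `N/C(=N\NC(=S)N1CCOCC1)c1ccc(F)cn1`: 85.6%

In a functional assay on A-431 cells (Homo sapiens) for cytotoxicity, read by MTT assay, with a stated time of 72 h, tested at 100 uM (a lower number here means less inhibition of growth, a higher number more inhibition of growth at the concentration tested), compound 2 stands second highest of the three numbers. Its nearest neighbour is compound 1; the step of a number 1.2 percentage points higher from compound 1 to compound 2 (within the scatter) is within the scatter. Compound 3 differs from compound 2 in two places. Compound 3 gives 85.6%, and that value also lies within the scatter of the value of compound 2.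

Compound 4, `N/C(=N\NC(=S)N1CCCCC1)c1ccccn1`, has not yet been measured in this assay. It differs from compound 2 by piperidin-1-yl in place of thiomorpholin-4-yl on a thiocarbonyl carbon. For the measured compounds named here, no measured step touches the ring on the thiocarbonyl carbon; the only measured step concerns a methyl on the aromatic ring, and it was within the scatter. Going by the values given here, compound 3 carries a different ring at this position but also a different aromatic ring, so no single step can be drawn from it. All three measured numbers sit close together, and compound 4 is therefore expected to show a step of a number 0.8 percentage points lower from compound 2 to compound 4 (within the scatter) that stays within the scatter. Compound 4 is estimated at 80%, with a range from 66% to 92%.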

Compound 4, percent growth inhibition at one concentration: 85.6%
For compound 4 the middle estimate is 5.6 percentage points below the measured one, within the range that was stated.
By their numbers in this assay, from the lowest: compounds 1, 2, 3 and 4 (each within the scatter of the next).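

In this assay, for the compounds shown here, the ring on the thiocarbonyl carbon is changed on its own for the first time, the only earlier step having concerned a methyl on an aromatic carbon. The exchange of thiomorpholin-4-yl for piperidin-1-yl gives a number 4.8 percentage points higher from compound 2 to compound 4 (within the scatter) and so shows that, on the core of compound 2, the ring sulfur is not needed to keep growth inhibition at the concentration tested. Nothing at hand explains how these two rings come to read alike.

The compounds shown leave open whether this position accepts a group other than a six-membered ring, such as an open dimethylamino group. They also leave open whether a larger ring, such as 4-methylpiperazin-1-yl with its second ring nitrogen, would stay in the same range.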